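Adding a Second Fluorine to the Benzoyl Ring

This account rests on a few compounds, and the source may have more. Where it says the series, first, only, none or still open, it means among the compounds named here.

Measured so far, in a functional assay on HeLa cells (Homo sapiens) for inhibition, read by MTT assay, with a stated time of 72 h; on this read-out lower numbers stand for stronger inhibition and higher numbers for weaker inhibition:
- compound 1 `CN(C(=O)NC(=O)c1ccc(F)c(F)c1)c1nc(C(F)(F)F)c(C(=O)N/N=C/c2cccc(C(F)(F)F)c2)s1` gives 4.21 ug/mL
- compound 2 `CN(C(=O)NC(=O)c1c(F)cccc1F)c1nc(C(F)(F)F)c(C(=O)N/N=C/c2ccc(C(F)(F)F)cc2)s1` gives 30.6 ug/mL
- compound 3 `CN(C(=O)NC(=O)c1ccccc1F)c1nc(C(F)(F)F)c(C(=O)N/N=C/c2cccc(C(F)(F)F)c2)s1` gives 19.1 ug/mL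

Compound 3 stands second highest of the three numbers in this assay. Its nearest neighbour is compound 2, whose value lies within the usual scatter of repeated measurements, so the two cannot be ranked against each other. Compound 1 sits clearly apart: the step of a 4.5-fold higher number from compound 1 to compound 3 (0.66 log units; beyond the scatter) is a modest rise in the number, beyond the scatter.

Compound 4 `CN(C(=O)NC(=O)c1c(F)cccc1F)c1nc(C(F)(F)F)c(C(=O)N/N=C/c2cccc(C(F)(F)F)c2)s1` differs from compound 3 in one place: fluoro in place of hydrogen on an aromatic carbon, so that the 2-fluorophenyl becomes a 2,6-difluorophenyl. Among the measured compounds shown here, no measured pair shows exactly this change. For the measured compounds named here, the only single-place step on record, from compound 1 to compound 3, concerns a different rearrangement of fluorines on the same ring. Compound 2 carries the 2,6-difluorophenyl that compound 4 will have, but it also carries its trifluoromethyl on a different carbon of the hydrazone ring, so its value and that of compound 3 show only that the two lie close together.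

With so little to go on, the expected step of a 1.3-fold higher number from compound 3 to compound 4 (0.10 log units; within the scatter) is small, within the scatter, with a slight lean toward a higher number. Compound 4 is therefore estimated at 24 ug/mL, within a range of 8 ug/mL to 65 ug/mL.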

Compound 4, half-maximal inhibitory concentration: 21.6 ug/mL
Estimate against measurement, compound 4: 1.1-fold (0.05 log units) above; measured number inside the range.
By their numbers in this assay, from the lowest: compound 1; then compounds 3, 4 and 2 (each within the scatter of the next).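

Fluoro in place of hydrogen on this aromatic carbon, ortho to a large group, turns the 2-fluorophenyl into a 2,6-difluorophenyl, and in this assay the direct step is a 1.1-fold higher number from compound 3 to compound 4 (0.05 log units; within the scatter), so this assay detects no effect of the change at this position. With the 2,6-difluorophenyl held fixed, the trifluoromethyl placement can now also be read as a single change: a 1.4-fold lower number from compound 2 to compound 4 (0.15 log units; within the scatter) shows that 3-(trifluoromethyl)phenyl and 4-(trifluoromethyl)phenyl cannot be told apart here. The clear gap lies elsewhere, with a 5.1-fold higher number from compound 1 to compound 4 (0.71 log units; beyond the scatter) separating two difluorophenyl groups, so among these compounds the placement of the fluorines on the ring matters more than the added fluoro tested in the step to compound 4.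

Nothing measured here indicates why the numbers fall as they do.

Every group on this ring among the compounds shown is a fluoro, so a chloro, a methoxy or an amine on this aromatic carbon remains an open question, as does whether the 3,4-difluorophenyl would keep its lower number alongside a 4-(trifluoromethyl)phenyl.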